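The compounds below may be only part of what the source reports. "The series", "measured", "known", "first", "only" and "open" are said of these compounds alone.

Of the compounds shown here, three of a shared core have been measured in a functional assay on NCI-H1975 cells (Homo sapiens) for inhibition, read by MTT assay, with a stated time of 72 h; a higher number here means a weaker inhibitor, a lower number a stronger inhibitor. Compound 1 `C=CC(=O)Nc1cccc(NC(=O)CSc2nc(Nc3ccccc3)c3ccccc3n2)c1` gives 8120 nM. Compound 2 `C=CC(=O)Nc1cccc(NC(=O)CSc2nc(Nc3ccccc3C)c3ccccc3n2)c1`, which carries a methyl in place of hydrogen on an aromatic carbon, gives 9920 nM; the step of a 1.2-fold higher number from compound 1 to compound 2 (0.09 log units; within the scatter) is within the scatter. Compound 3 `C=CC(=O)Nc1cccc(NC(=O)CSc2nc(Nc3ccc(F)cc3)c3ccccc3n2)c1` gives 4430 nM. Compound 3 stands at the low end of the three: against compound 1 the step of a 1.8-fold lower number from compound 1 to compound 3 (0.26 log units; within the scatter) stays within the scatter, so those two cannot be told apart, while against compound 2 the step of a 2.2-fold lower number from compound 2 to compound 3 (0.35 log units; beyond the scatter) is modest but beyond the scatter.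

Compound 4 `C=CC(=O)Nc1cccc(NC(=O)CSc2nc(Nc3ccc(Cl)c(Cl)c3)c3ccccc3n2)c1` has not been measured. It differs from compound 3 in one place: 3,4-dichlorophenyl in place of 4-fluorophenyl on a nitrogen on an aromatic ring. Within the data shown here, no measured step swaps one halogenated ring for another, so the bearing of the known steps is indirect. Among the measured compounds shown here, the only halogen step, a 1.8-fold lower number from compound 1 to compound 3 (0.26 log units; within the scatter), was small, and the ring swap a 2.2-fold lower number from compound 2 to compound 3 (0.35 log units; beyond the scatter) was modest. The expectation for compound 4 is therefore a change in this assay no larger than a 1.3-fold lower number from compound 3 to compound 4 (0.10 log units; within the scatter), in either direction, with a slight lean toward a lower number. Compound 4 is estimated at 3500 nM, between 1200 nM and 10000 nM.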

Compound 4, half-maximal inhibitory concentration: 19100 nM
Compound 4: middle estimate off by 5.5-fold (0.74 log units), on the low side; measured number outside the range, above it.
By their numbers in this assay, from the lowest: compounds 3, 1, 2 and 4 (each within the scatter of the next, the first and the last beyond it).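

In this assay, the halogens on the ring at this nitrogen are not interchangeable: exchanging 4-fluorophenyl for 3,4-dichlorophenyl gives a 4.3-fold higher number from compound 3 to compound 4 (0.63 log units; beyond the scatter), the largest step yet seen among these compounds, so carrying halogen on this ring does not in itself bring a lower number. Replacing the plain phenyl with 3,4-dichlorophenyl gives a 2.4-fold higher number from compound 1 to compound 4 (0.37 log units; beyond the scatter), a rise beyond the scatter, whereas the 4-fluorophenyl ring could not be told apart from plain phenyl, so this position does respond to what the ring carries. The 2-methylphenyl ring is a different matter: the exchange gives a 1.9-fold higher number from compound 2 to compound 4 (0.28 log units; within the scatter), which means that these two rings cannot be told apart here, although they carry different groups.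

Nothing measured on these compounds accounts for the rise in the number. As far as these compounds go, it also stays open whether a ring with a single chlorine would fall with 3,4-dichlorophenyl or with 4-fluorophenyl, and what a ring bearing a methoxy group or an amine would give at this nitrogen.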